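The source may report more compounds than this note shows. Statements on the series, on what has been measured and on what is new or still open speak of the compounds shown alone.

Working notes on a short series of three measured compounds and one still to be measured.

Compound 1 `CCCCCCCCNC(=O)[C@@H](NC(=O)c1cccs1)[C@@H](C)O` is the parent; in a functional assay on SiHa cells (Homo sapiens) for cytotoxicity, read by MTT assay, with a stated time of 48 h (a lower number here means a stronger inhibitor, a higher number a weaker inhibitor), compound 1 gives 91900 nM. Compound 2 `CCCCCCCCNC(=O)[C@@H](NC(=O)c1cc2ccccc2o1)[C@@H](C)O` differs from compound 1 by 1-benzofuran-2-yl in place of thiophen-2-yl on a carbonyl carbon and in this assay compound 2 gives 66500 nM, a step of a 1.4-fold lower number from compound 1 to compound 2 (0.14 log units; within the scatter). Compound 3 `CCCCCCCCCCCCCCCCCCNC(=O)[C@@H](NC(=O)c1cccs1)[C@@H](C)O` differs from compound 1 by decyl in place of hydrogen on a saturated chain carbon, eight bonds along the chain from an amide-type nitrogen; in this assay compound 3 gives 117000 nM, a step of a 1.3-fold higher number from compound 1 to compound 3 (0.10 log units; within the scatter). All three values sit within the scatter of one another, so no ordering among them is claimed.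

Compound 4 `CCCCCCCCCCCCCCCCCCNC(=O)[C@@H](NC(=O)c1cc2ccccc2o1)[C@@H](C)O` is not yet measured. It stands to compound 3 as compound 2 stands to compound 1: the change 1-benzofuran-2-yl in place of thiophen-2-yl on a carbonyl carbon is the same change as that from compound 1 to compound 2, the place being identical in both pairs, while the two cores differ by decyl in place of hydrogen on a saturated chain carbon, eight bonds along the chain from an amide-type nitrogen. The earlier step, a 1.4-fold lower number from compound 1 to compound 2 (0.14 log units; within the scatter), was within the scatter, and the decyl extension did little in a 1.3-fold higher number from compound 1 to compound 3 (0.10 log units; within the scatter). The expected step from compound 3 to compound 4 in this assay is therefore a 1.4-fold lower number from compound 3 to compound 4 (0.14 log units; within the scatter). Compound 4 is estimated at 85000 nM in this assay, with a likely range from 40000 nM to 180000 nM.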

Compound 4, half-maximal inhibitory concentration: > 200000 nM
Compound 4: no number, only a limit; the forecaster's own chance of this, stated with the estimate: 10%; at least 2.3-fold (0.37 log units) between middle value and limit.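

In this assay compound 4 reads as a limit of the assay, not a number: the limit of > 200000 nM in this assay, at which 1 of the 4 values shown sits.

Carried onto the core of compound 3, the change to 1-benzofuran-2-yl gives an at least 1.7-fold higher number from compound 3 to compound 4 (0.23 log units; that floor lies within the scatter), so the change cannot be said to carry over unchanged, nor to behave differently on the two cores: the same change on two cores in this assay, a 1.4-fold lower number (0.14 log units; within the scatter) from compound 1 to compound 2 and an at least 1.7-fold higher number (0.23 log units; that floor lies within the scatter) from compound 3 to compound 4; the limit leaves it open whether they differ

The decyl extension, read with 1-benzofuran-2-yl in place, gives an at least 3.0-fold higher number from compound 2 to compound 4 (0.47 log units; beyond the scatter), which is beyond the scatter, yet this does not establish that it acts differently from the same extension with thiophen-2-yl in place: the same change on two cores in this assay, a 1.3-fold higher number (0.10 log units; within the scatter) from compound 1 to compound 3 and an at least 3.0-fold higher number (0.47 log units; beyond the scatter) from compound 2 to compound 4; the limit leaves it open whether they differ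

From the compounds shown here alone, with only a limit for compound 4, the size of its step remains open, and so does any interplay of the 1-benzofuran-2-yl group with the decyl extension. The compounds shown also leave open how a shorter extension such as hexyl, or an amine or a carboxylic acid on the chain, would read with either ring.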